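From 2-Methoxyphenyl to 4-Ethoxyphenyl on a Shared Core

The source may report more compounds than this note shows. Statements on the series, on what has been measured and on what is new or still open speak of the compounds shown alone.

The shared core of compound 1 `COc1cc(-c2ccc3ncn(-c4cc(OC)c(OC)c(OC)c4)c3c2)cc(OC)c1OC` carries a varying aryl group on an aromatic carbon. In a functional assay on MCF7 cells (Homo sapiens) for antiproliferative activity, read by MTT assay, with a stated time of 72 h (a lower number here means a stronger inhibitor, a higher number a weaker inhibitor), compound 1 reports only a limit of the assay, > 10000 nM, which is the limit of > 10000 nM in this assay, at which 1 of the 3 values shown sits. Compound 2 `COc1cccc(-c2ccc3ncn(-c4cc(OC)c(OC)c(OC)c4)c3c2)c1` gives 1610 nM in this assay, and compound 3 `COc1ccccc1-c1ccc2ncn(-c3cc(OC)c(OC)c(OC)c3)c2c1` gives 1750 nM. The step of a 1.1-fold higher number from compound 2 to compound 3 (0.04 log units; within the scatter) leaves compound 3 standing with compound 2 as one of the two numbers measured, neither apart from the other. Compound 4 `CCOc1ccc(-c2ccc3ncn(-c4cc(OC)c(OC)c(OC)c4)c3c2)cc1` differs from compound 3 by 4-ethoxyphenyl in place of 2-methoxyphenyl on an aromatic carbon. Among the measured compounds shown here, no measured step tests a 4-ethoxyphenyl group, and the one measured step, a 1.1-fold higher number from compound 2 to compound 3 (0.04 log units; within the scatter), gives no reason to expect a step beyond the scatter. Compound 4 is therefore expected to give about 1800 nM, between 600 nM and 6000 nM, an estimated step of a 1.0-fold higher number from compound 3 to compound 4 (0.01 log units; within the scatter).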

Compound 4, half-maximal inhibitory concentration: 1710 nM
For compound 4 the middle estimate is 1.1-fold (0.02 log units) above the measured one; low and high end bracket the measured number.
By their numbers in this assay, from the lowest: compounds 2, 4 and 3 (each within the scatter of the next). At a limit, above all of these: compound 1.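

In this assay the step of a 1.0-fold lower number from compound 3 to compound 4 (0.01 log units; within the scatter) and the step of a 1.1-fold higher number from compound 2 to compound 4 (0.03 log units; within the scatter) show that 4-ethoxyphenyl stands level with both methoxyphenyl groups on this aromatic carbon, with no order among the three. The earlier pair had shown such closeness only between two methoxyphenyl groups, and now it extends to a phenyl group carrying an ethoxy chain. On these data alone, whether an amine, a carboxylic acid or a longer chain on this phenyl group would also leave the number in place stays open. No measurement shown gives a reason for this closeness.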